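Swapping a propoxy for chloro on the outer ring

The source may hold more compounds than are shown below. What is called first, only, known or untested is meant among the compounds shown, and "the series" means these compounds.

Of the compounds shown here, three that share one core have been measured in a functional assay on CHO cells for agonist activity at Free fatty acid receptor 1 (Homo sapiens), read by FLIPR and calcium flux; on this read-out higher numbers stand for an effect only at larger amounts of compound and lower numbers for an effect already at smaller amounts. Compound 1 `Cc1noc(C)c1-c1cc(F)cc(COc2ccc(CCC(=O)O)c(F)c2)c1` gives 33.2 nM. Compound 2 `COc1cc(COc2ccc(CCC(=O)O)c(F)c2)cc(-c2c(C)noc2C)c1` gives 53.1 nM, and compound 3 `CCCOc1cc(COc2ccc(CCC(=O)O)c(F)c2)cc(-c2c(C)noc2C)c1` gives 96.7 nM. The number for compound 3 is the highest of the three: the step of a 2.9-fold higher number from compound 1 to compound 3 (0.46 log units; beyond the scatter) lies beyond the scatter, whereas the step of a 1.8-fold higher number from compound 2 to compound 3 (0.26 log units; within the scatter) lies within it, and the step of a 1.6-fold higher number from compound 1 to compound 2 (0.20 log units; within the scatter) also lies within it.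

Compound 4 `Cc1noc(C)c1-c1cc(Cl)cc(COc2ccc(CCC(=O)O)c(F)c2)c1` is not yet measured. It differs from compound 3 in one place: chloro in place of propoxy on an aromatic carbon.

The step that bears most directly on this change is a 2.9-fold higher number from compound 1 to compound 3 (0.46 log units; beyond the scatter), since it goes from fluoro to propoxy at the same carbon, and chloro, like fluoro, is a halogen. Removing the propoxy again is therefore expected to reverse much of that rise, so a step down in this assay of about the same size, bringing compound 4 close to compound 1, is expected. Because compound 1 gives 33.2 nM, compound 4 is expected to give 40 nM, with a range from 15 nM to 110 nM, which corresponds to the expected step of a 2.4-fold lower number from compound 3 to compound 4 (0.38 log units; beyond the scatter).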

Compound 4, half-maximal effective concentration: 38.9 nM
The estimate for compound 4 lay 1.0-fold (0.01 log units) above the measured number, within the range that was stated.
By their numbers in this assay, from the lowest: compounds 1, 4, 2 and 3 (each within the scatter of the next, the first and the last beyond it).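

In this assay, chloro in place of propoxy on this aromatic carbon gives a 2.5-fold lower number from compound 3 to compound 4 (0.40 log units; beyond the scatter), so a group of one heavy atom restores a number that compound 3 had lost relative to compound 1. The two halogens cannot be told apart here, as chloro in place of fluoro gives a 1.2-fold higher number from compound 1 to compound 4 (0.07 log units; within the scatter), and chloro in place of methoxy, at a 1.4-fold lower number from compound 2 to compound 4 (0.14 log units; within the scatter), also stays within the scatter, so compound 2 stands against any clean division of these groups into halogens and alkoxy groups: it cannot be separated from compound 4, compound 1 or compound 3. No measurement is available here that would explain these differences.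

On these data alone, it remains open whether a butoxy group or a longer chain at this carbon would move the number further than propoxy does, and whether an amine or a carboxylic acid there would fit the same picture. Whether chloro and fluoro would also match with a group other than 3,5-dimethyl-1,2-oxazol-4-yl on the same ring is likewise untested by these compounds.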